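Amide nitrogen substituents on the thiazolidinedione series

This account rests on a few compounds, and the source may have more. Where it says the series, first, only, none or still open, it means among the compounds named here.

For the measured compounds named here, compound 3 `Cc1cccc2sc(NC(=O)COc3ccc4cc(/C=C5/SC(=O)NC5=O)ccc4c3)nc12` gives 1200 nM in an assay on isolated protein for inhibition of histone deacetylase 4 (Homo sapiens), with a stated time of 1 h (a higher number here means a weaker inhibitor, a lower number a stronger inhibitor), the lowest of the three numbers so far. Compound 1 `COc1cccc(NC(=O)COc2ccc3cc(/C=C4/SC(=O)NC4=O)ccc3c2)c1` gives 1600 nM in this assay, and the step of a 1.3-fold lower number from compound 1 to compound 3 (0.12 log units; within the scatter) stays within the scatter. Compound 2 `O=C(COc1ccc2cc(/C=C3/SC(=O)NC3=O)ccc2c1)Nc1ccc(F)cc1F` gives 3900 nM in this assay, and the step of a 3.3-fold lower number from compound 2 to compound 3 (0.51 log units; beyond the scatter) is beyond the scatter.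

Compound 4 `O=C(COc1ccc2cc(/C=C3/SC(=O)NC3=O)ccc2c1)Nc1cc(Cl)cc(C(F)(F)F)c1` differs from compound 3 in one place: 3-chloro-5-(trifluoromethyl)phenyl in place of 4-methyl-1,3-benzothiazol-2-yl on an amide-type nitrogen. Going by the values given here, no measured step matches this exchange. The nearest are the two steps at the same nitrogen: a 2.4-fold higher number from compound 1 to compound 2 (0.39 log units; beyond the scatter) and a 3.3-fold lower number from compound 2 to compound 3 (0.51 log units; beyond the scatter). The one measured phenyl carrying halogen, compound 2, gave the highest number, and its replacement by the benzothiazolyl of compound 3 gave the lowest. Among the compounds with values here, compound 4 returns to a halogen-bearing phenyl, so a modest rise in this assay is expected, of about a 2.5-fold higher number from compound 3 to compound 4 (0.40 log units; beyond the scatter), though the chloro and trifluoromethyl groups have no measured precedent here. Compound 4 is therefore estimated at 3000 nM in this assay, with a range from 1200 nM to 7500 nM.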

Compound 4, half-maximal inhibitory concentration: 4000 nM
Compound 4: middle estimate off by 1.3-fold (0.12 log units), on the low side, within the range that was stated.
By their numbers in this assay, from the lowest: compounds 3 and 1 (each within the scatter of the next); then compounds 2 and 4 (each within the scatter of the next).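

In this assay, a second halogen-bearing phenyl falls with the first (a 1.0-fold higher number from compound 2 to compound 4 (0.01 log units; within the scatter)): exchanging 2,4-difluorophenyl for 3-chloro-5-(trifluoromethyl)phenyl on the amide-type nitrogen produces no readable change. Compound 4 also stands apart from the other two substituents (a 3.3-fold higher number from compound 3 to compound 4 (0.52 log units; beyond the scatter); a 2.5-fold higher number from compound 1 to compound 4 (0.40 log units; beyond the scatter)). Among these four compounds the numbers therefore split into two groups, with the halogen-bearing phenyls of compound 2 and compound 4 on the higher side and none of the four going against this.

No available evidence accounts for this split. From the compounds shown here alone, it remains open whether a phenyl carrying an amine or a carboxylic acid would group with compound 1 or compound 2, and whether a phenyl carrying chlorine alone or trifluoromethyl alone would group with compound 4.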